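Swapping a dimethylphenyl for a bromophenyl on the core

This account rests on a few compounds, and the source may have more. Where it says the series, first, only, none or still open, it means among the compounds named here.

Going by the values given here, compound 1 `CSc1ccc(C2=C(c3ccc(C)c(C)c3)C(=O)N3CCCC3C2)cc1` gives 300 nM in a functional assay on SK-OV-3 cells (Homo sapiens) for cytotoxicity (on this read-out lower numbers stand for stronger inhibition of growth and higher numbers for weaker inhibition of growth), the lowest of the two numbers known here; compound 2 `COc1ccc(C2=C(c3ccc(SC)cc3)CC3CCCN3C2=O)cc1OC` gives 9000 nM, a much higher number. Compound 3 `CSc1ccc(C2=C(c3ccc(Br)cc3)C(=O)N3CCCC3C2)cc1` has not yet been tested. It differs from compound 1 in one place: 4-bromophenyl in place of 3,4-dimethylphenyl on a double-bonded ring carbon. Among the compounds with values here, no step between two measured compounds that differ in a single place is available, so the size of this change is open. A modest step is expected, plausibly toward weaker inhibition of growth, as a 1.7-fold higher number from compound 1 to compound 3 (0.22 log units; within the scatter). Compound 3 is therefore estimated at 500 nM, within a range from 150 nM to 2000 nM.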

Compound 3, concentration for 50% growth inhibition: 9000 nM
The estimate for compound 3 lay 18-fold (1.26 log units) below the measured number; measured number above the stated range.
By their numbers in this assay, from the lowest: compound 1; then compounds 2 and 3 (each within the scatter of the next).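

Going by these compounds alone, the change of 4-bromophenyl in place of 3,4-dimethylphenyl on a double-bonded ring carbon brings a 30-fold higher number from compound 1 to compound 3 (1.48 log units; beyond the scatter) in this assay and is the first single-place step available here. It shows that growth inhibition depends strongly on the group at this position, even though both groups hold one six-membered aromatic ring of carbon only. No measurement at hand accounts for the size of this step.

Two methyl groups and one bromine differ here, so the step cannot be assigned to either alone. As far as these compounds go, how a plain phenyl, a pyridine ring or a cyclohexyl group would fare at this position remains open.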